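The compounds below may be only part of what the source reports. "The series", "measured", "known", "first", "only" and "open" are said of these compounds alone.

Measured in a functional assay on A549 cells (Homo sapiens) for cytotoxicity, read by MTT assay, with a stated time of 72 h; a lower number here means a stronger inhibitor, a higher number a weaker inhibitor:
- Compound 1 `COc1cc(/C=C2\CN(C)C/C(=C\c3cc(OC)c(OC)c(OC)c3)C2=O)cc(OC)c1OC`: 1700 nM
- Compound 2 `COc1ccc(/C=C2\CN(C)C/C(=C\c3ccc(OC)c(OC)c3)C2=O)cc1OC`: 1300 nM

The two values lie within the scatter of each other, so compound 1 stands level with compound 2 and neither can be ranked above the other. The next compound to be tested is compound 3 `CCC(=O)N1C/C(=C\c2cc(OC)c(OC)c(OC)c2)C(=O)/C(=C/c2cc(OC)c(OC)c(OC)c2)C1`. It keeps the core of compound 1 but carries propanoyl in place of methyl on an amine nitrogen in a ring. Going by the values given here, no measured pair of compounds shows what this change does, so any expectation here is loose and the range must stay wide. A modest move towards stronger inhibition in this assay is expected, estimated as a 2.1-fold lower number from compound 1 to compound 3 (0.33 log units; beyond the scatter). For compound 3 the expected value is 800 nM, with an estimated range from 200 nM to 3000 nM.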

Compound 3, half-maximal inhibitory concentration: 800 nM
Compound 3: the middle estimate sits on the measured number at the digits printed, within the range that was stated.
By their numbers in this assay, from the lowest: compounds 3, 2 and 1 (each within the scatter of the next, the first and the last beyond it).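

In this assay, going by these compounds alone, the amine nitrogen in the ring proved open to change: replacing methyl with propanoyl gives a 2.1-fold lower number from compound 1 to compound 3 (0.33 log units; beyond the scatter) and so provides the first reading at this position. The step is modest, but it shows that this larger group, which brings a carbonyl and one hydrogen-bond acceptor, keeps the activity of the shared core and moves the number lower. No measurement offered here explains the step.

The compounds shown leave open whether the carbonyl or the length of the chain matters, which acetyl, butanoyl or a plain propyl group on the same nitrogen could separate. As far as these compounds go, it also remains open whether propanoyl would bring a similar step on the core of compound 2, or how a free amine hydrogen at this nitrogen would compare.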